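Pyrazolylamine swap on the aminonitrile series

The compounds below may be only part of what the source reports. "The series", "measured", "known", "first", "only" and "open" are said of these compounds alone.

Measured so far, all in an assay on isolated protein for binding affinity to Leucine-rich repeat serine/threonine-protein kinase 2 variant G2019S (Homo sapiens), read by TR-FRET and LanthaScreen, with a stated time of 2 h; a higher number here means a weaker inhibitor, a lower number a stronger inhibitor:
- compound 1 `Cc1c(Nc2nc(N)c3c(C#N)c(N4CCC[C@H]4C)n(C)c3n2)cnn1C`: in this assay compound 1 gives 3 nM
- compound 2 `Cn1c(NCc2ccccc2)c(C#N)c2c(N)ncnc21`: in this assay compound 2 gives 243 nM
- compound 3 `C[C@@H]1CCCN1c1c(C#N)c2c(N)nc(Nc3ccn(C)n3)cc2n1C`: in this assay compound 3 gives 13 nM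

Compound 1 holds the lowest number of the three. Its nearest neighbour on the numbers is compound 3, which sits beyond the scatter above it; compound 2 lies furthest, also well beyond the scatter. None of these pairs differ in only one place, so no single-change step can be read from them.

Compound 4 `Cc1n[nH]cc1Nc1nc(N)c2c(C#N)c(N3CCC[C@H]3C)n(C)c2n1` has not yet been measured in this assay. It differs from compound 1 by 3-methyl-1H-pyrazol-4-yl in place of 1,5-dimethyl-1H-pyrazol-4-yl on a nitrogen on an aromatic ring; one methyl is lost from the pyrazole, and a ring hydrogen-bond donor appears where none was before.

Going by the values given here, no measured step of this kind exists, so the size of the change is an open question. The expectation is a small step only, at most slightly weaker, and quite possibly none beyond the scatter, with the step from compound 1 to compound 4 estimated as a 1.7-fold higher number from compound 1 to compound 4 (0.22 log units; within the scatter). Compound 4 is therefore expected at about 5 nM in this assay, estimated to fall between 1.5 nM and 15 nM.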

Compound 4, inhibition constant: 2 nM
Compound 4: the middle estimate sits 2.5-fold (0.40 log units) above what was measured; measured number inside the range.
By their numbers in this assay, from the lowest: compounds 4 and 1 (each within the scatter of the next); then compound 3; then compound 2.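

In this assay, placing 3-methyl-1H-pyrazol-4-yl where 1,5-dimethyl-1H-pyrazol-4-yl stood, on a nitrogen on an aromatic ring, gives a 1.5-fold lower number from compound 1 to compound 4 (0.18 log units; within the scatter), so this pair shows no difference that can be told apart from repeat scatter. Going by these compounds alone, this is the first comparison that differs in one place, and it shows that at this position the lost methyl and the hydrogen-bond donor that enters with the new group together leave the binding reading unmoved within that scatter, with compound 4 at 2 nM in this assay. Nothing at hand bears on why the two compounds read alike.

Because the methyl count and the ring hydrogen-bond donor change together in this one step, their separate contributions stay unresolved, and either could be offsetting the other. Also open, going by these compounds, is how much room the group has at this position: whether an ethyl, a methoxy or a longer chain on the pyrazole would hold the number in this assay remains to be seen.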